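The compounds below may be only part of what the source reports. "The series", "measured", "known", "first", "only" and "open" are said of these compounds alone.

Compound 1 `N#Cc1cc(F)cc(C(=O)Nc2ccccn2)c1`: 3010 nM
Compound 2 `N#Cc1cc(F)cc(C(=O)Nc2nccs2)c1`: > 10000 nM
Compound 3 `N#Cc1cc(F)cc(C(=O)Nc2cccc(C(F)(F)F)n2)c1`: > 10000 nM

In an in vitro functional assay on HEK293-A cells for antagonist activity at metabotropic glutamate receptor 5 (Rattus norvegicus), read by calcium flux (on this read-out lower numbers stand for stronger inhibition and higher numbers for weaker inhibition), compound 1 gives 3010 nM. Compound 2 reaches only a limit of the measurement, > 10000 nM. Compound 3 likewise reaches only a limit, > 10000 nM, so for compound 3 no number is known, only that it lies at the weak end of what this assay can report; it shares this position with compound 2, as the limit of > 10000 nM in this assay, at which 2 of the 3 values shown sit, shows.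

Two measured steps lead away from compound 1. Swapping its ring gave an at least 3.3-fold higher number from compound 1 to compound 2 (0.52 log units; beyond the scatter). Adding a trifluoromethyl gave an at least 3.3-fold higher number from compound 1 to compound 3 (0.52 log units; beyond the scatter).

Compound 4 `COc1cccc(NC(=O)c2cc(F)cc(C#N)c2)n1` differs from compound 3 in one place: methoxy in place of trifluoromethyl on an aromatic carbon. Within the data shown here, of the measured steps, only the one from compound 1 to compound 3 touches this position, and it shows that a trifluoromethyl there costs at least a modest amount. A methoxy is a different, smaller group, so compound 4 is estimated to lie between compound 3 and compound 1, with an expected step of an at least 2.5-fold lower number from compound 3 to compound 4 (0.39 log units; beyond the scatter). Compound 4 is therefore expected at 4000 nM, within 1000 nM to 10000 nM.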

Compound 4, half-maximal inhibitory concentration: 1510 nM
Beside the measured number, compound 4's estimate is 2.6-fold (0.42 log units) above it; the measured number falls inside the stated range.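

Methoxy in place of trifluoromethyl on this aromatic carbon, next to the ring nitrogen, gives an at least 6.6-fold lower number from compound 3 to compound 4 (0.82 log units; beyond the scatter), so the loss seen with trifluoromethyl does not extend to every group placed here. Set against hydrogen at the same carbon, methoxy gives a 2.0-fold lower number from compound 1 to compound 4 (0.30 log units; within the scatter), and this step lies within the scatter, so in this assay the two groups cannot be told apart at this position, and a group can stand here without a measurable penalty. The true size of the step away from compound 3 stays unknown, since the value of compound 3 is only a limit and not a number: the limit of > 10000 nM in this assay, at which 2 of the 4 values shown sit.

The compounds shown carry only hydrogen, methoxy and trifluoromethyl at this carbon, so three groups are too few to show what separates a tolerated group from a costly one. As far as these compounds go, an amine, a chlorine atom or a longer chain such as ethoxy at the same place could fall on either side, and whether any group here can give a number clearly lower than that of hydrogen remains open.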